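The source may hold more compounds than are shown below. What is called first, only, known or untested is meant among the compounds shown, and "the series" means these compounds.

Two compounds built on the same core, each carrying a furan ring and an amino group, differ only in which pyridyl sits on a saturated chain carbon bound to a nitrogen on an aromatic ring. In a functional assay on CHO cells for agonist activity at adenosine receptor A2b (Homo sapiens), read by scintillation counting and cAMP accumulation, with a stated time of 150 min, in the presence of a further agent that is not named here (on this read-out lower numbers stand for stronger inhibition and higher numbers for weaker inhibition), compound 1 `Nc1nc(NCc2ccncc2)nc2sc(-c3ccco3)nc12` gives 33 nM. Compound 2 `Nc1nc(NCc2ccccn2)nc2sc(-c3ccco3)nc12` gives 95 nM in this assay, the higher of the two numbers, and the move between them is a 2.9-fold higher number from compound 1 to compound 2 (0.46 log units; beyond the scatter). Compound 3 `Nc1nc(NCc2cccnc2)nc2sc(-c3ccco3)nc12` has not been measured in this assay; it is compound 2 rearranged, with pyridin-3-yl in place of pyridin-2-yl on a saturated chain carbon bound to a nitrogen on an aromatic ring. Among the measured compounds shown here, only one measured step bears on this, a 2.9-fold higher number from compound 1 to compound 2 (0.46 log units; beyond the scatter), a modest shift when the pyridyl is exchanged. A step of similar size, toward the lower number of compound 1, is therefore the most reasonable expectation, and the expected step is a 2.1-fold lower number from compound 2 to compound 3 (0.32 log units; beyond the scatter). Compound 3 is estimated to give 45 nM, with a range from 15 nM to 140 nM.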

Compound 3, half-maximal inhibitory concentration: 109 nM
Beside the measured number, compound 3's estimate is 2.4-fold (0.38 log units) below it; measured number inside the range.
By their numbers in this assay, from the lowest: compound 1; then compounds 2 and 3 (each within the scatter of the next).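

Exchanging pyridin-2-yl for pyridin-3-yl on this saturated chain carbon gives a 1.1-fold higher number from compound 2 to compound 3 (0.06 log units; within the scatter), so this assay does not separate these two groups at this place. Pyridin-4-yl now stands apart from both of them, with pyridin-3-yl in its place giving a 3.3-fold higher number from compound 1 to compound 3 (0.52 log units; beyond the scatter), which matches the size of the earlier step to pyridin-2-yl and shows that this group alone gives the lower number among the three. No measurement at hand explains why pyridin-4-yl differs from the other two.

The compounds shown leave open whether a pyridyl ring is needed here at all, which a plain phenyl ring on the same carbon would test, and whether a longer chain carrying pyridin-4-yl would keep its lower number. They also leave open whether this difference among the pyridyl groups would hold with a thiophene in place of the furan ring.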